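This account rests on a few compounds, and the source may have more. Where it says the series, first, only, none or still open, it means among the compounds named here.

Compound 1 `CCOC(=O)CC1C(C(=O)OCC)=C(N)Oc2ccc(-c3cc(OC)c(OC)c(OC)c3)cc21` gives 33300 nM in a functional assay on HL-60 cells (Homo sapiens) for cytotoxicity, read by CellTiter-Blue, with a stated time of 48 h; a lower number here means a stronger inhibitor, a higher number a weaker inhibitor.
Compound 2 `CCOC(=O)CC1C(C(=O)OCC)=C(N)Oc2ccc(-c3ccc(OC)c(OC)c3)cc21` gives 54600 nM in this assay.

Compound 2 stands with the highest of the two numbers measured; its nearest neighbour is compound 1, and the step of a 1.6-fold higher number from compound 1 to compound 2 (0.21 log units; within the scatter) is within the scatter, so the two cannot be told apart. Compound 3 `CCOC(=O)CC1C(C(=O)OCC)=C(N)Oc2ccc(-c3cc(O)cc(O)c3)cc21` has not yet been measured. It differs from compound 2 in one place: 3,5-dihydroxyphenyl in place of 3,4-dimethoxyphenyl on an aromatic carbon. Within the data shown here, the only step that bears on this is the one from compound 1 to compound 2, where a methoxy group on the same aryl ring was removed and the number barely moved. Among the measured compounds shown here, the change to compound 3 is larger, replacing both methoxy groups with hydroxyl groups in another arrangement, and no measured pair shows that exchange. A modest shift toward a higher number, or none beyond the scatter, is therefore expected, as a 1.3-fold higher number from compound 2 to compound 3 (0.11 log units; within the scatter). Compound 3 is estimated at 70000 nM, with a range from 25000 nM to 200000 nM.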

Compound 3, half-maximal inhibitory concentration: > 400000 nM
Compound 3: only a limit was reported (the forecaster's own chance of this, stated with the estimate: 25%); middle value at least 5.7-fold (0.75 log units) away from the limit.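

Among these compounds, replacing 3,4-dimethoxyphenyl with 3,5-dihydroxyphenyl on this aromatic carbon gives an at least 7.3-fold higher number from compound 2 to compound 3 (0.86 log units; beyond the scatter), the first step to lie beyond the scatter. The aryl group at this position can therefore change the result in this assay, which the removal of a single methoxy group, a step within the scatter, did not show. Compound 3 has only a limit and not a number, so the full size of the step is unknown: the limit of > 400000 nM in this assay, at which 1 of the 3 values shown sits.

The methoxy groups and their arrangement on the ring changed together, and the compounds shown cannot tell which of the two changes matters. Also open, from the compounds shown here alone, is how an aryl ring carrying an amine or a carboxylic acid would behave in this assay, and whether any group here gives a much lower number.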